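A few compounds are considered here, and "the series" means these few. Any claim that something is new, unique, unknown or untested is made for them only; others in the source may bear on it.

Series notes. Compound 1 `CCCn1cnc2ncnc(N)c21` carries the shared core with a propyl chain on the aromatic nitrogen. In an assay on CHO cells for displacement of a labelled ligand from adenosine receptor A3 (Homo sapiens) (a lower number here means a stronger inhibitor, a higher number a weaker inhibitor), compound 1 gives > 100000 nM, which is a limit of the assay rather than a number (the limit of > 100000 nM in this assay, at which 1 of the 3 values shown sits). Compound 2 `Nc1ncnc2c1nc(Br)n2CCCO` adds a bromine and a 3-hydroxypropyl chain, and in this assay compound 2 gives 3200 nM. Compound 3 `CC(O)Cn1c(Br)nc2c(N)ncnc21` keeps the bromine with a 2-hydroxypropyl chain. In this assay compound 3 gives >= 100000 nM, again a limit of the assay and not a number (the limit of >= 100000 nM in this assay, at which 1 of the 3 values shown sits). Going by the values given here, the only single-place step among the measured compounds is an at least 31-fold higher number from compound 2 to compound 3 (1.49 log units; beyond the scatter), so compound 3 stands at the weak end of what has been measured.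

Compound 4 `Nc1ncnc2c1nc(Br)n2CC(O)CO` differs from compound 3 by hydroxy in place of hydrogen on a saturated chain carbon, two bonds along the chain from an oxygen on a saturated carbon; the same difference read one bond further out is methyl to hydroxymethyl, 1-hydroxyethyl to 1,2-dihydroxyethyl, 2-hydroxypropyl to 2,3-dihydroxypropyl. Among the compounds with values here, no measured step adds a hydroxy at this place. The bearing evidence is an at least 31-fold higher number from compound 2 to compound 3 (1.49 log units; beyond the scatter): moving the single hydroxyl cost a large step, and compound 4 carries a hydroxyl at both chain positions, so some return toward compound 2 is plausible but not secured. Compound 3 is only a limit, which leaves the size of the step unanchored. Compound 4 is expected at 20000 nM in this assay, within 3000 nM to 100000 nM. The expected step of an at least 5.0-fold lower number from compound 3 to compound 4 (0.69 log units; beyond the scatter) points toward a lower number.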

Compound 4, inhibition constant: >= 100000 nM
Compound 4 gave a limit, no number; the forecaster's own chance of this, stated with the estimate: 40%; middle value at least 5.0-fold (0.69 log units) from the limit.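

Adding hydroxy to the 2-hydroxypropyl chain, to give the 2,3-dihydroxypropyl chain of compound 4, does not bring back a readable number in this assay, and the step between compound 3 and compound 4 cannot be read. Set against compound 2, the same chain shows a large loss for hydroxy in place of hydrogen on a saturated chain carbon bound to two saturated chain carbons, an at least 31-fold higher number from compound 2 to compound 4 (1.49 log units; beyond the scatter), so the hydroxy of the 3-hydroxypropyl chain does not keep the value once this second hydroxy enters. Two different single-place changes from compound 2 now end at the same limit of the assay, and compound 2 remains the only one of the four compounds with a number: the limit of >= 100000 nM in this assay, at which 2 of the 4 values shown sit.

Going by these compounds, how far compound 3 and compound 4 lie past that limit stays unknown, so the two chains cannot be ranked against each other. Also open, on these data alone, is whether an amine or a carboxylic acid at this place of the chain, or a longer chain ending in hydroxy, would hold or improve on compound 2, which gives 3200 nM.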